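Curcumin-like dienones: a sulfo-to-hydroxy swap on the side chain

The compounds below may be only part of what the source reports. "The series", "measured", "known", "first", "only" and "open" are said of these compounds alone.

Measured compounds and their values:
Compound 1 `COc1ccc(/C=C2\CN(C(=O)CCSCCS(=O)(=O)O)C/C(=C\c3ccc(OC)cc3)C2=O)cc1` gives 91700 nM in a functional assay on HSC-4 cells (Homo sapiens) for cytotoxicity, read by MTT assay, with a stated time of 48 h; a lower number here means that less compound is tolerated, a higher number that more compound is tolerated.
Compound 2 `O=C1/C(=C/c2ccc(Cl)cc2)CN(C(=O)CCSCCS(=O)(=O)O)C/C1=C\c1ccc(Cl)cc1` gives 29700 nM.
Compound 3 `O=C1/C(=C/c2ccc([N+](=O)[O-])cc2)CN(C(=O)CCSCCS(=O)(=O)O)C/C1=C\c1ccc([N+](=O)[O-])cc1` gives 4730 nM.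

Compound 3 has the lowest number of the three, and its gaps to compound 2 and to compound 1 both lie beyond the usual scatter, so it is the least tolerated of the measured set. Compound 4 `O=C1/C(=C/c2ccc([N+](=O)[O-])cc2)CN(C(=O)CCSCCO)C/C1=C\c1ccc([N+](=O)[O-])cc1` keeps the core of compound 3 and differs only in the side chain: hydroxy in place of sulfo on a saturated chain carbon, two bonds along the chain from a sulfur. Among the compounds with values here, no pair of measured compounds differs in just this place, so the direction rests on expectation alone. A modest step toward a lower number is expected for compound 4, a 1.9-fold lower number from compound 3 to compound 4 (0.28 log units; within the scatter), and its value in this assay is estimated at 2500 nM, within a range of 800 nM to 8000 nM.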

Compound 4, half-maximal cytotoxic concentration: 390 nM
The estimate for compound 4 lay 6.4-fold (0.81 log units) above the measured number, and the stated range ends above it.
By their numbers in this assay, from the lowest: compound 4; then compound 3; then compound 2; then compound 1.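

In this assay the end of the side chain turns out to count heavily: on the core of compound 3, hydroxy in place of sulfo gives a 12-fold lower number from compound 3 to compound 4 (1.08 log units; beyond the scatter), well beyond the scatter. The earlier compounds shown here all carried the same side chain, so they could say nothing about this position. Nothing measured here accounts for the size of this step. On these data alone, it remains open whether the swap would act similarly on the cores of compound 1 and compound 2, and what a carboxylic acid, an amine or a longer chain would give at this place.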